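Amide-Side Substitution in a Weakly Cytotoxic Series

The compounds below may be only part of what the source reports. "The series", "measured", "known", "first", "only" and "open" are said of these compounds alone.

compound 1 `C=CC1=C(C(=O)NCCCCC)C(c2ccc(OC)cc2)OC1`: 36500 nM
compound 2 `C=CC1=C(C(=O)NCCCCC)C(c2ccc(F)cc2)OC1`: > 100000 nM (a limit, not a number)

Among the compounds with values here, in a functional assay on A549 cells (Homo sapiens) for cytotoxicity, read by MTT assay, with a stated time of 24 h (on this read-out higher numbers stand for weaker inhibition and lower numbers for stronger inhibition), compound 1 gives 36500 nM and so carries the only number in the set, a weak one. For compound 2 the assay reports only a limit, (the limit of > 100000 nM in this assay, at which 1 of the 2 values shown sits). The step of an at least 2.7-fold higher number from compound 1 to compound 2 (0.43 log units; beyond the scatter) is therefore itself a bound rather than a measured size. Compound 3 `C=CC1=C(C(=O)NCc2ccccc2F)C(c2ccc(OC)cc2)OC1` differs from compound 1 at the amide end: 2-fluorophenyl in place of butyl on a saturated chain carbon bound to an amide-type nitrogen. No measured step touches this part of the molecule; the single step shown concerns fluoro in place of methoxy on an aromatic carbon and gives no guidance on the amide substituent. The expectation for compound 3 rests on compound 1 alone and stays wide. Compound 3 is estimated at 30000 nM, range 8000 nM to 100000 nM. The step of a 1.2-fold lower number from compound 1 to compound 3 (0.09 log units; within the scatter) is expected to stay within the scatter, with a real chance that only a limit is returned.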

Compound 3, half-maximal inhibitory concentration: > 100000 nM
Compound 3: a limit, no number; the forecaster's own chance of this, stated with the estimate: 30%; middle value at least 3.3-fold (0.52 log units) away from the limit.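

In this assay compound 3 returns > 100000 nM, a limit and not a number. The amide end is therefore not a neutral place on this core: 2-fluorophenyl in place of butyl on a saturated chain carbon bound to an amide-type nitrogen gives an at least 2.7-fold higher number from compound 1 to compound 3 (0.43 log units; beyond the scatter), and this size is a bound, not a measured one. Changes at two separate places on compound 1 now end at a limit, which leaves compound 1 as the only compound with a number and gives no way to rank the two changes: the limit of > 100000 nM in this assay, at which 2 of the 3 values shown sit.

The compounds shown do not separate the aromatic ring of 2-fluorobenzyl from its fluorine, since unsubstituted benzyl is not among them. As far as these compounds go, how a longer chain or a chain ending in an amine would read at this position, and whether any amide substituent gives a lower number than compound 1, stays open.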